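Aryl amine change from compound 3 to compound 4

A few compounds are considered here, and "the series" means these few. Any claim that something is new, unique, unknown or untested is made for them only; others in the source may bear on it.

Compound 3 `Cc1ccc(S(=O)(=O)c2nc3ccccc3nc2Nc2cccc(O)c2)cc1` gives 6080 nM in a functional assay on A549 cells (Homo sapiens) for cytotoxicity, read by MTT assay, with a stated time of 72 h (on this read-out lower numbers stand for stronger inhibition and higher numbers for weaker inhibition), the lowest of the two numbers shown. Compound 2 `COc1cc(Nc2nc3ccccc3nc2S(=O)(=O)c2ccc(C)cc2)cc(OC)c1` gives 8060 nM, and a 1.3-fold lower number from compound 2 to compound 3 (0.12 log units; within the scatter). Compound 1 `COc1ccc(Nc2nc3ccccc3nc2S(=O)(=O)c2ccc(C)cc2)cc1` returns only a limit, > 50000 nM. Compound 4 `Cc1ccc(S(=O)(=O)c2nc3ccccc3nc2Nc2ccc(C(F)(F)F)cc2)cc1` carries 4-(trifluoromethyl)phenyl in place of 3-hydroxyphenyl on a nitrogen on an aromatic ring. The measured steps that bear on this are an at least 8.2-fold lower number from compound 1 to compound 3 (0.91 log units; beyond the scatter) and an at least 6.2-fold lower number from compound 1 to compound 2 (0.79 log units; beyond the scatter); both leave 4-methoxyphenyl, whose compound sits at the limit of > 50000 nM in this assay, at which 1 of the 3 values shown sits. Compound 4 returns to a 4-substituted phenyl, now 4-(trifluoromethyl)phenyl, without the donor or acceptor of 3-hydroxyphenyl, so a weakening is expected; the expected step is a 4.1-fold higher number from compound 3 to compound 4 (0.61 log units; beyond the scatter). Compound 4 is expected to give 25000 nM, with a range from 7000 nM to 50000 nM and a real chance of only a limit.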

Compound 4, half-maximal inhibitory concentration: 13500 nM
For compound 4 the middle estimate is 1.9-fold (0.27 log units) above the measured one, within the range that was stated.
By their numbers in this assay, from the lowest: compounds 3, 2 and 4 (each within the scatter of the next, the first and the last beyond it). At a limit, above all of these: compound 1.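

With 4-(trifluoromethyl)phenyl on the nitrogen, a group with no hydrogen-bond donor or acceptor still gives a measurable value: an at least 3.7-fold lower number from compound 1 to compound 4 (0.56 log units; beyond the scatter). Replacing 3-hydroxyphenyl gives a modest loss, a 2.2-fold higher number from compound 3 to compound 4 (0.35 log units; beyond the scatter), while the comparison with 3,5-dimethoxyphenyl gives a 1.7-fold higher number from compound 2 to compound 4 (0.22 log units; within the scatter). Compound 1 remains a limit rather than a number: the limit of > 50000 nM in this assay, at which 1 of the 4 values shown sits.

On these data alone, the size of the gain from methoxy to trifluoromethyl stays unknown. Also open, as far as these compounds go, is how a carboxylic acid or an amine on the same phenyl ring would read.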